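The source may hold more compounds than are shown below. What is called first, only, known or untested is meant among the compounds shown, and "the series" means these compounds.

Three compounds of this series carry the same 2,4-dioxobutanoic acid chain and have been measured in an assay on isolated protein (Sus scrofa) for inhibition of 2-Hydroxyacid oxidase 1 (Homo sapiens); a lower number here means a stronger inhibitor, a higher number a weaker inhibitor. Compound 1 `CC1=C(/C=C/C(=O)CC(=O)C(=O)O)C(C)(C)CCC1` gives 1400 nM, compound 2 `CCCCCCCCCc1ccc(C(=O)CC(=O)C(=O)O)cc1` gives 600 nM, and compound 3 `O=C(O)C(=O)CC(=O)c1ccc(-c2ccccc2)cc1` gives 1100 nM. Compound 3 stands second highest of the three numbers; its nearest neighbour is compound 1, its furthest compound 2, and both gaps fall within the usual scatter, so the three numbers cannot be ordered against each other.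

Compound 4 `O=C(O)C(=O)CC(=O)c1ccc(-c2ccc(Br)cc2)cc1` has not yet been measured in this assay. It differs from compound 3 in one place: bromo in place of hydrogen on an aromatic carbon. Cut one bond further out, the same difference reads phenyl to 4-bromophenyl.

Going by the values given here, no step between measured compounds isolates this change, and nothing among the three measured compounds points to a large move in either direction. The step in this assay from compound 3 to compound 4 is therefore expected to be small, if anything a modest decrease of the number, a 1.4-fold lower number from compound 3 to compound 4 (0.14 log units; within the scatter). For compound 4 an estimate of 800 nM in this assay is made, with a range from 300 nM to 2500 nM, and a measured value is awaited.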

Compound 4, half-maximal inhibitory concentration: 63 nM
Estimate against measurement, compound 4: 13-fold (1.10 log units) above; the whole stated range lies above it.
By their numbers in this assay, from the lowest: compound 4; then compounds 2, 3 and 1 (each within the scatter of the next, the first and the last beyond it).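

In this assay, going by these compounds alone, phenyl to 4-bromophenyl gives a 17-fold lower number from compound 3 to compound 4 (1.24 log units; beyond the scatter), the first step to lie beyond the scatter and the only one so far that isolates a single place. Within the data shown here, this aromatic carbon, para to a large group, is therefore not indifferent: one entering heavy atom, with no hydrogen-bond donor or acceptor and no net charge, is enough to separate two otherwise identical compounds, something the earlier three numbers, each within the scatter of the next and linked by no single-place step, could not show. Nothing at hand bears on the origin of this step.

On these data alone, whether the step is specific to bromo remains open: chloro, a methyl group, a methoxy group or a carboxylic acid on the same aromatic carbon would show whether other groups there give a step of similar size. Also open, as far as these compounds go, is whether bromo on another carbon of that ring would match this step, and whether the same change would carry over to a different group on the shared 2,4-dioxobutanoic acid chain.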